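Propanoyl ester of compound 1: expected outcome

The source may report more compounds than this note shows. Statements on the series, on what has been measured and on what is new or still open speak of the compounds shown alone.

compound 1 `OC1CCN(c2ccc(-c3ccc(Cl)cc3Cl)nn2)CC1` — 8.5 mg/kg
compound 2 `Cc1cc(Cl)ccc1-c1ccc(N2CCC(O)CC2)nn1` — 10 mg/kg
compound 3 `O=C1CCN(c2ccc(-c3ccc(Cl)cc3Cl)nn2)CC1` — 7.3 mg/kg

In a functional assay on the whole organism with Mus musculus as the target (on this read-out higher numbers stand for an effect only at larger amounts of compound and lower numbers for an effect already at smaller amounts), compound 1 gives 8.5 mg/kg, the second highest of the three numbers; compound 3 gives 7.3 mg/kg and compound 2 gives 10 mg/kg, both within the scatter of compound 1. Compound 4 `CCC(=O)OC1CCN(c2ccc(-c3ccc(Cl)cc3Cl)nn2)CC1` differs from compound 1 by propanoyl in place of hydrogen on an oxygen on a saturated carbon. Within the data shown here, the one measured step at the same oxygen is a 1.2-fold lower number from compound 1 to compound 3 (0.07 log units; within the scatter); the other, a 1.2-fold higher number from compound 1 to compound 2 (0.07 log units; within the scatter), changes a different place. Among the measured compounds shown here, neither step moves beyond the scatter, and no measured pair shows a propanoyl group entering. For compound 4 the expectation is therefore no step beyond the scatter, no change at the digits printed from compound 1 to compound 4 (within the scatter). Compound 4 is estimated at 8.5 mg/kg, with a range from 4 mg/kg to 18 mg/kg.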

Compound 4, dose for half-maximal effect: 16 mg/kg
For compound 4 the middle estimate is 1.9-fold (0.27 log units) below the measured one; the measured number falls inside the stated range.
By their numbers in this assay, from the lowest: compounds 3, 1, 2 and 4 (each within the scatter of the next, the first and the last beyond it).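

In this assay the change from hydroxy to propanoyloxy gives a 1.9-fold higher number from compound 1 to compound 4 (0.27 log units; within the scatter) and so stays within the scatter. This oxygen on a saturated carbon therefore carries propanoyl, a group with no hydrogen-bond donor, without a step beyond the scatter, so the hydrogen of compound 1 is not required at this read-out. The compounds shown leave open whether an amine, a carboxylic acid or an acyl chain longer than propanoyl at this place would also stay within the scatter. Nothing available bears on what lies behind the size of this step.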